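The source may hold more compounds than are shown below. What is called first, only, known or untested is meant among the compounds shown, and "the series" means these compounds.

Measured compounds:
Compound 1 `NS(=O)(=O)NCC1CCN(c2cc(-c3ccc(Cl)cc3)ncn2)CC1`: 50300 nM
Compound 2 `COc1ccccc1-c1cc(N2CCC(CNS(N)(=O)=O)CC2)ncn1`: > 100000 nM

In a functional assay on M21 cells (Homo sapiens) for antiproliferative activity, read by sulforhodamine B assay, with a stated time of 48 h (a lower number here means a stronger inhibitor of growth, a higher number a weaker inhibitor of growth), compound 1 gives 50300 nM, a weak effect on cell growth. Compound 2 gives only > 100000 nM; this is a limit of the assay and not a measured number, as the limit of > 100000 nM in this assay, at which 1 of the 2 values shown sits, makes plain. Among the measured compounds shown here, the one measured step, an at least 1.9-fold higher number from compound 1 to compound 2 (0.29 log units; that floor lies within the scatter), therefore tells only that compound 2 is no stronger than compound 1, and its floor lies within the scatter.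

Compound 3 `NS(=O)(=O)NCC1CCN(c2cc(-c3ccccc3Cl)ncn2)CC1` differs from compound 2 by chloro in place of methoxy on an aromatic carbon. For the measured compounds named here, no measured step covers this exact change; the nearest comparison is the pair above, where a 4-chlorophenyl and a 2-methoxyphenyl gave two numbers that could not be told apart. Both measured compounds sit at the weak end, so compound 3 is expected to land near them as well, with an at least 1.2-fold lower number from compound 2 to compound 3 (0.09 log units; that floor lies within the scatter) as a modest expected move back toward the number seen for compound 1. For compound 3 the estimated value in this assay is 80000 nM, within a range from 30000 nM to 200000 nM, with a fair chance that only a limit is reported.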

Compound 3, concentration for 50% growth inhibition: > 100000 nM
Compound 3 was reported as a limit; the forecaster's own chance of this, stated with the estimate: 40%; middle value at least 1.2-fold (0.09 log units) away from the limit.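

Compound 3 ends at a limit of the assay and not at a number. With 2-chlorophenyl in place of 4-chlorophenyl, the result is an at least 1.9-fold higher number from compound 1 to compound 3 (0.29 log units; that floor lies within the scatter), so moving the chloro on this ring brings no gain in growth inhibition over compound 1, and how much is lost, if anything, cannot be told. The step from methoxy to chloro on an aromatic carbon, ortho to a large group, cannot be read at all, and most of this small set now gives no number to compare: the limit of > 100000 nM in this assay, at which 2 of the 3 values shown sit.

From the compounds shown here alone, it remains open how far compound 2 and compound 3 really lie from compound 1, and whether any group on this ring can give a clearly stronger inhibitor of growth than compound 1, which gives 50300 nM. A 4-methoxyphenyl group would separate the effect of the group from that of its place on the ring, while an amine or a carboxylic acid in the same place would test a quite different kind of group.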